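The compounds below may be only part of what the source reports. "The series", "measured", "known", "first", "only" and "open" are said of these compounds alone.

Within the data shown here, in a functional assay on MDA-MB-231 cells (Homo sapiens) for antiproliferative activity, read by MTT assay (a lower number here means a stronger inhibitor, a higher number a weaker inhibitor), compound 3 (`CCCCC/C=C\C/C=C\CCCCCCCC1(O)CC(=O)c2c(O)cc(OCOC)cc2O1`) gives 16100 nM, the highest number so far, while compound 1 (`CCCCCCCCCCCCCCCC1(O)CC(=O)c2c(O)cc(O)cc2O1`) gives 6790 nM and compound 2 (`CC/C=C\C/C=C\C/C=C\CCCCCCCC1(O)CC(=O)c2c(O)cc(OCOC)cc2O1`) gives 6790 nM. Compound 4 (`CCCCCCCCCCCCCCCC1(O)CC(=O)c2c(O)cc(OCOC)cc2O1`) has octyl in place of deca-1,4-dien-1-yl on a saturated chain carbon, seven bonds along the chain from a saturated ring carbon. Among the measured compounds shown here, only one measured step bears directly on this change: a 2.4-fold higher number from compound 2 to compound 3 (0.37 log units; beyond the scatter), a modest rise on losing a chain double bond. Against a further rise stands compound 1, whose chain is also saturated, at 6790 nM. The expected change is therefore small and upward, and it may stay within the scatter. The expected step is a 1.1-fold higher number from compound 3 to compound 4 (0.05 log units; within the scatter). For compound 4 the estimated value is 18000 nM, with an expected range of 7000 nM to 45000 nM.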

Compound 4, half-maximal inhibitory concentration: > 87000 nM
Compound 4 ended at the assay's limit (the forecaster's own chance of this, stated with the estimate: 5%); middle value at least 4.8-fold (0.68 log units) from the limit.
By their numbers in this assay, from the lowest: compounds 1 and 2 (each within the scatter of the next); then compound 3. At a limit, above all of these: compound 4.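

Compound 4 sits at a limit of the assay, not at a measured number: the limit of > 87000 nM in this assay, at which 1 of the 4 values shown sits. With both chain double bonds gone, the numbers rise sharply, with an at least 5.4-fold higher number from compound 3 to compound 4 (0.73 log units; beyond the scatter) and an at least 12-fold higher number from compound 2 to compound 4 (1.10 log units; beyond the scatter). On this saturated chain the oxygen substituent also counts, since methoxymethyl in place of hydrogen on an oxygen on an aromatic ring gives an at least 12-fold higher number from compound 1 to compound 4 (1.10 log units; beyond the scatter). Going by these compounds, what a chain with a single double bond would give remains open. So does whether a methyl group on that oxygen would behave like methoxymethyl.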